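A Trimethoxyphenyl Swap on a Compound at the Limit

The source may hold more compounds than are shown below. What is called first, only, known or untested is meant among the compounds shown, and "the series" means these compounds.

In a functional assay on PC-3 cells (Homo sapiens) for antiproliferative activity, read by MTT assay, with a stated time of 48 h (a lower number here means a stronger inhibitor, a higher number a weaker inhibitor), compound 1 `O=C(/C=C\Nc1ccc(F)cc1)c1cn(-c2ccccc2)nc1-c1ccccc1` gives 7980 nM and compound 3 `O=C(/C=C\Nc1ccc(O)cc1)c1cn(-c2ccccc2)nc1-c1ccccc1` gives 3600 nM. Compound 2 `O=C(/C=C\Nc1ccc(C(F)(F)F)cc1)c1cn(-c2ccccc2)nc1-c1ccccc1` gives > 50000 nM, which is a limit of the assay and not a number. Compound 4 `COc1cc(-c2nn(-c3ccccc3)cc2C(=O)/C=C\Nc2ccc(C(F)(F)F)cc2)cc(OC)c1OC` differs from compound 2 by having 3,4,5-trimethoxyphenyl in place of phenyl on an aromatic carbon.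

Within the data shown here, no measured step touches that carbon, so the evidence is only indirect. The three measured changes all swap fluoro, trifluoromethyl or hydroxy on an aromatic carbon elsewhere in the molecule. They gave an at least 6.2-fold higher number from compound 1 to compound 2 (0.79 log units; beyond the scatter), a 2.2-fold lower number from compound 1 to compound 3 (0.35 log units; beyond the scatter) and an at least 13-fold lower number from compound 2 to compound 3 (1.14 log units; beyond the scatter). Among these three compounds, then, one swap moved the number by a modest to large amount. Compound 2 has no exact number, so only a move to a lower number could show here, and a modest one is expected. The estimated change is an at least 2.5-fold lower number from compound 2 to compound 4 (0.39 log units; beyond the scatter). For compound 4 the estimate is 20000 nM, with an expected range of 4000 nM to 50000 nM.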

Compound 4, half-maximal inhibitory concentration: > 50000 nM
Compound 4: only a limit was reported (the forecaster's own chance of this, stated with the estimate: 35%); middle value at least 2.5-fold (0.39 log units) away from the limit.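

The step from compound 2 to compound 4 cannot be read, since both compounds sit at the same assay limit and neither has an exact number: the limit of > 50000 nM in this assay, at which 2 of the 4 values shown sit.

The compounds shown leave open whether 3,4,5-trimethoxyphenyl in place of phenyl moves the number at all, and in which direction.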